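A few compounds are considered here, and "the series" means these few. Any claim that something is new, unique, unknown or untested is made for them only; others in the source may bear on it.

Compound 2 `Cc1cn([C@@H]2O[C@H](CO[Si](C)(C)C(C)(C)C)[C@@]3(OS(=O)(=O)C=C3NC(=O)NCc3ccccc3)[C@H]2O[Si](C)(C)C(C)(C)C)c(=O)n(C)c1=O` and compound 1 `Cc1cn([C@@H]2O[C@H](CO[Si](C)(C)C(C)(C)C)[C@@]3(OS(=O)(=O)C=C3NC(=O)N(C(=O)Nc3ccccc3)c3ccccc3)[C@H]2O[Si](C)(C)C(C)(C)C)c(=O)n(C)c1=O` share the same core and differ only at the urea end. In an ADME assay on HEL cells (Homo sapiens) for cytotoxicity, with a stated time of 3 days (a lower number here means that less compound is tolerated, a higher number that more compound is tolerated), compound 2 gives 4000 nM, the lowest of the two numbers measured, so it is the less tolerated of the pair. Compound 1 gives 46000 nM in this assay, a higher number that lies beyond the usual scatter. Compound 3 `CCOC(=O)NC(=O)NC1=CS(=O)(=O)O[C@@]12[C@@H](CO[Si](C)(C)C(C)(C)C)O[C@@H](n1cc(C)c(=O)n(C)c1=O)[C@@H]2O[Si](C)(C)C(C)(C)C` has not yet been tested in this assay. It differs from compound 2 in a single place: ethoxycarbonyl in place of benzyl on an amide-type nitrogen. Among the compounds with values here, no measured pair shows this change, so there is no direct guide to its size. The step is expected to be upward, toward a better-tolerated compound, and modest, a 3.0-fold higher number from compound 2 to compound 3 (0.48 log units; beyond the scatter), since the two measured numbers leave room on either side. Compound 3 is therefore estimated to give 12000 nM in this assay, with a likely range from 3500 nM to 50000 nM.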

Compound 3, minimum cytotoxic concentration: 10000 nM
Compound 3: the middle estimate sits 1.2-fold (0.08 log units) above what was measured; the measured number falls inside the stated range.
By their numbers in this assay, from the lowest: compound 2; then compound 3; then compound 1.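

In this assay, within the data shown here, the swap of benzyl for ethoxycarbonyl on the amide-type nitrogen gives a 2.5-fold higher number from compound 2 to compound 3 (0.40 log units; beyond the scatter) and so provides the first single-place reading at this end of the urea. It shows that this position responds to the change, with more compound tolerated once the aromatic ring of benzyl gives way to a group with no ring. Nothing shown here bears on why the number rises.

The step removes the aromatic ring and brings in the ethoxycarbonyl carbonyl at the same time, and the compounds shown do not separate these two parts of the change. They also leave open how a longer chain such as butoxycarbonyl, or a small group such as acetyl, would behave on this nitrogen.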